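The source may report more compounds than this note shows. Statements on the series, on what has been measured and on what is new or still open speak of the compounds shown alone.

Three compounds have been measured in a functional assay on Jurkat cells (Homo sapiens) for inhibition; a higher number here means a weaker inhibitor, a lower number a stronger inhibitor:

Compound 1, `CCOC(=O)c1cnc(N(C(=O)c2ccccc2)N2C(=O)C=C(C)C2=O)nc1C(F)(F)F`, gives 830 nM.
Compound 2, `CCOC(=O)c1cnc(N(C(=O)OCC)N2C(=O)C=C(C)C2=O)nc1C(F)(F)F`, gives 380 nM.
Compound 3, `CCOC(=O)c1cnc(N(C)N2C(=O)C=C(C)C2=O)nc1CC`, gives 35 nM.

Compounds 1 and 2 differ in one place: phenyl in place of ethoxy on a carbonyl carbon. This change gives a 2.2-fold higher number from compound 2 to compound 1 (0.34 log units; beyond the scatter). Compound 3 has the lowest number of the three in this assay; its core differs from that of compound 2 in more than one place, and the difference between the two cores is not broken down here.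

Compound 4, `CCc1nc(N(C)N2C(=O)C=C(C)C2=O)ncc1C(=O)c1ccccc1`, is not yet measured. It differs from compound 3 as follows: phenyl in place of ethoxy on a carbonyl carbon. This is the same kind of change as that from compound 2 to compound 1, not the same change: there the carbonyl carbon's other neighbour is an amide-type nitrogen, here it is an aromatic carbon. Within the data shown here, only the step from compound 2 to compound 1 stands as a precedent, so the expectation for compound 4 rests on a single pair and on a carbonyl carbon in different surroundings. Compound 4 is expected to give 75 nM in this assay, between 20 nM and 300 nM, an expected step of a 2.1-fold higher number from compound 3 to compound 4 (0.33 log units; beyond the scatter), beside the earlier step of a 2.2-fold higher number from compound 2 to compound 1 (0.34 log units; beyond the scatter).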

Compound 4, half-maximal inhibitory concentration: 410 nM
For compound 4 the middle estimate is 5.5-fold (0.74 log units) below the measured one; measured number above the stated range.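

In this assay, phenyl in place of ethoxy on a carbonyl carbon gives a 12-fold higher number from compound 3 to compound 4 (1.07 log units; beyond the scatter), and the size of this step does not carry over from the earlier pair: the same change on two cores in this assay, a 2.2-fold higher number (0.34 log units; beyond the scatter) from compound 2 to compound 1 and a 12-fold higher number (1.07 log units; beyond the scatter) from compound 3 to compound 4, 5.4-fold (0.73 log units) apart, beyond the scatter of two such steps. The direction does carry over, with the number rising in both pairs, but the earlier step would have been a poor guide to the size of the new one. The two pairs do not show what sets the sizes apart, as the carbonyl carbon's other neighbour and the rest of the core differ together, and two pairs give no rule for a third core.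

The compounds shown leave open which of the differences in the core goes with the larger step, for instance the ethyl of compound 3 as against the trifluoromethyl of compound 2. They also leave open how an amine or a methyl in place of ethoxy on the carbonyl carbon of the core of compound 3 would read in this assay.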